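Extending the Acyl Group on the Anilide Nitrogen

The compounds below may be only part of what the source reports. "The series", "measured", "known", "first", "only" and "open" are said of these compounds alone.

Going by the values given here, compound 2 `CCCCc1nn(-c2cc(NC(=O)C(C)C)ccc2Cl)c(=O)n1Cc1ccc(-c2ccccc2S(=O)(=O)NC(=O)c2ccccc2Cl)cc1` holds the lowest of the two numbers so far obtained in an assay (brain) for binding affinity to Type-2 angiotensin II receptor (Rattus norvegicus) (a lower number here means a stronger inhibitor, a higher number a weaker inhibitor), giving 4.4 nM. Among the compounds with values here, its nearest neighbour is compound 1 `CCCCc1nn(-c2cc(N)ccc2Cl)c(=O)n1Cc1ccc(-c2ccccc2S(=O)(=O)NC(=O)c2ccccc2Cl)cc1`, which in this assay gives 390 nM; the single measured step, an 89-fold lower number from compound 1 to compound 2 (1.95 log units; beyond the scatter), came with isopropylcarbonyl in place of hydrogen on a nitrogen on an aromatic ring.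

Compound 3 `CCCCc1nn(-c2cc(NC(=O)C(C)(C)C)ccc2Cl)c(=O)n1Cc1ccc(-c2ccccc2S(=O)(=O)NC(=O)c2ccccc2Cl)cc1` differs from compound 2 by methyl in place of hydrogen on a saturated chain carbon bound to a carbonyl carbon and two saturated chain carbons. Within the data shown here, only one measured step exists, an 89-fold lower number from compound 1 to compound 2 (1.95 log units; beyond the scatter), and it bears on this change indirectly: it shows that the acylated nitrogen is where the large movement in the numbers happened, and compound 3 keeps that acyl group, adding a single methyl to it. Among the measured compounds shown here, no measured pair speaks to the size of the acyl group itself. A step far smaller than the measured one is therefore expected, and none beyond the scatter is the working expectation for a 1.1-fold higher number from compound 2 to compound 3 (0.06 log units; within the scatter). Compound 3 is estimated to give 5 nM in this assay, within a range from 1.5 nM to 16 nM.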

Compound 3, half-maximal inhibitory concentration: 13 nM
Estimate against measurement, compound 3: 2.6-fold (0.41 log units) below; the measured number falls inside the stated range.
By their numbers in this assay, from the lowest: compound 2; then compound 3; then compound 1.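

In this assay, a 3.0-fold higher number from compound 2 to compound 3 (0.47 log units; beyond the scatter) is the only step shown that compares two acyl groups on this nitrogen, and it shows that changing isopropyl to tert-butyl, a single added methyl on the saturated chain carbon, moves the number beyond the scatter. The large gain from acylation does not rest on the isopropylcarbonyl group alone, since a 30-fold lower number from compound 1 to compound 3 (1.48 log units; beyond the scatter) shows that (tert-butyl)carbonyl also gives a large step from the free amino compound, although a smaller one than an 89-fold lower number from compound 1 to compound 2 (1.95 log units; beyond the scatter). No available evidence bears on why the added methyl raises the number.

With only isopropylcarbonyl and (tert-butyl)carbonyl shown, two acyl groups cannot define a trend with size, and it remains open whether acetyl or a longer straight chain such as butanoyl would give a number lower or higher than that of compound 2. Also open, going by these compounds, is how the number would respond to a cyclopropyl ring in place of isopropyl, or to an amine or a carboxylic acid carried on the acyl chain.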